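Replacing a Larger Side Chain with Methyl on the Aniline Ring

This account rests on a few compounds, and the source may have more. Where it says the series, first, only, none or still open, it means among the compounds named here.

Compound 1 `c1ccc(Nc2nccc(-c3ccco3)n2)cc1`: 32000 nM
Compound 2 `COc1cccc(Nc2nccc(-c3ccco3)n2)c1`: 400 nM
Compound 3 `c1cc(Nc2nccc(-c3ccco3)n2)cc(OCCn2ccnc2)c1`: 200 nM

In a functional assay for inhibition, with Homo sapiens as the target (on this read-out higher numbers stand for weaker inhibition and lower numbers for stronger inhibition), compound 1 gives 32000 nM, compound 2 gives 400 nM and compound 3 gives 200 nM. Compound 3 stands at the lowest number of the three, but its gap to compound 2 is within the scatter, so the two cannot be ranked; only compound 1 is clearly apart, shown by a 160-fold lower number from compound 1 to compound 3 (2.20 log units; beyond the scatter).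

Compound 4 `Cc1cccc(Nc2nccc(-c3ccco3)n2)c1` differs from compound 3 in one place: methyl in place of 2-(1H-imidazol-1-yl)ethoxy on an aromatic carbon. Within the data shown here, two measured steps bear on this. The step of an 80-fold lower number from compound 1 to compound 2 (1.90 log units; beyond the scatter) and the step of a 160-fold lower number from compound 1 to compound 3 (2.20 log units; beyond the scatter) both show that adding a group at this position, whether methoxy or the longer 2-(1H-imidazol-1-yl)ethoxy, lowers the number strongly compared with hydrogen, while the step of a 2.0-fold lower number from compound 2 to compound 3 (0.30 log units; within the scatter) shows that the two groups themselves are indistinguishable here. Methyl has not been tested; it is neither hydrogen nor an oxygen-linked group, so a number somewhere between compound 1 and compound 3 is expected, with wide uncertainty. Compound 4 is therefore estimated at 1500 nM (range 300 nM to 8000 nM), which means an expected step of a 7.5-fold higher number from compound 3 to compound 4 (0.88 log units; beyond the scatter).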

Compound 4, half-maximal inhibitory concentration: 2100 nM
Estimate against measurement, compound 4: 1.4-fold (0.15 log units) below, and the stated range covers the measured number.
By their numbers in this assay, from the lowest: compounds 3 and 2 (each within the scatter of the next); then compound 4; then compound 1.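

Even a single carbon at this aromatic position matters, as methyl in place of hydrogen gives a 15-fold lower number from compound 1 to compound 4 (1.18 log units; beyond the scatter) (large) in this assay. Methyl does not match either oxygen-linked group, though: replacing methoxy gives a 5.3-fold higher number from compound 2 to compound 4 (0.72 log units; beyond the scatter) (modest), and replacing 2-(1H-imidazol-1-yl)ethoxy gives an 11-fold higher number from compound 3 to compound 4 (1.02 log units; beyond the scatter) (large), so a group on this carbon lowers the number to different extents depending on which group it is, and the three substituted compounds do not form a single level. Why methoxy and 2-(1H-imidazol-1-yl)ethoxy give lower numbers than methyl cannot be said, as nothing available explains the difference.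

Still open, going by these compounds, is how other groups on the same aromatic carbon would behave, such as an ethyl, a hydroxyl, an amine or a chlorine atom, and whether any of them would come closer to compound 2 and compound 3 than methyl does. On these data alone, it is also open whether a longer chain ending in something other than the imidazole ring, such as an amine or a carboxylic acid, would match compound 3.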